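A few compounds are considered here, and "the series" means these few. Any claim that something is new, unique, unknown or untested is made for them only; others in the source may bear on it.

In a functional assay on A549 cells (Homo sapiens) for antiproliferative activity, read by MTT assay, with a stated time of 48 h (a higher number here means a weaker inhibitor, a lower number a stronger inhibitor), compound 2 `Cn1cc(C2=C(c3nn(CCCN4CCCCC4)c4ncccc34)C(=O)NC2=O)c2ccccc21` gives > 100000 nM, which is a limit of the assay and not a number. Compound 1 `Cn1cc(C2=C(c3nn(CCCN4CCCCC4)c4ncccc34)C(=O)N(c3ccccn3)C2=O)c2ccccc21` gives > 100000 nM, which is also a limit. All the evidence so far therefore reads as the limit of > 100000 nM in this assay, at which 2 of the 2 values shown sit. Compound 3 `COc1ccc(N2C(=O)C(c3cn(C)c4ccccc34)=C(c3nn(CCCN4CCCCC4)c4ncccc34)C2=O)cc1` departs from compound 2 at a single place, with 4-methoxyphenyl in place of hydrogen on an amide-type nitrogen in a ring. For the measured compounds named here, the only measured step touches that same nitrogen, with hydrogen in place of pyridin-2-yl, and it is a step that the two limits leave unreadable from compound 1 to compound 2. It supplies no size to carry over to the new substituent, and neither compound offers a number to start from. The expectation is thus a weak one: a ring on this nitrogen, as in compound 1, has not brought a readable value, so compound 3 will most likely stay at or close to the limit in this assay, with any movement toward stronger inhibition being modest. The expected step is an at least 1.4-fold lower number from compound 2 to compound 3 (0.15 log units; that floor lies within the scatter). For compound 3 the estimate is 70000 nM, with an expected range from 15000 nM to 100000 nM.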

Compound 3, half-maximal inhibitory concentration: 30300 nM
Estimate against measurement, compound 3: 2.3-fold (0.36 log units) above; measured number inside the range.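

Placing 4-methoxyphenyl on the amide-type nitrogen of the five-membered non-aromatic ring gives the series its first readable number in this assay, with an at least 3.3-fold lower number from compound 2 to compound 3 (0.51 log units; beyond the scatter). A ring on that nitrogen is therefore not enough by itself: compound 1 carries pyridin-2-yl there and gives only a limit of the assay, and exchanging it for 4-methoxyphenyl brings an at least 3.3-fold lower number from compound 1 to compound 3 (0.51 log units; beyond the scatter). Both steps are floors rather than full sizes, and the step from compound 1 to compound 2 remains unreadable, with the other values resting on a limit and not on a number: the limit of > 100000 nM in this assay, at which 2 of the 3 values shown sit.

The compounds shown do not separate the methoxy group from the phenyl ring that carries it, so it stays open whether a plain phenyl, a 4-hydroxyphenyl or a 4-chlorophenyl on the same nitrogen would give a similar number in this assay. From the compounds shown here alone, it is also open whether the nitrogen needs an aromatic ring at all, or whether a benzyl group or a simple methyl there would move the number off the limit as well.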